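The source may report more compounds than this note shows. Statements on the series, on what has been measured and on what is new or still open speak of the compounds shown alone.

In a functional assay on DU-145 cells (Homo sapiens) for antiproliferative activity, read by MTT assay, with a stated time of 48 h (on this read-out higher numbers stand for weaker inhibition and lower numbers for stronger inhibition), compound 1 (`C#CCOC(=O)/C(C)=C/CC/C(C)=C/CC/C(C)=C/CC[C@@H]1[C@@]2(C)CCC(=O)C(C)(C)[C@H]2CC[C@@]1(C)O`) gives 46100 nM and compound 2 (`C/C(=C\CC/C(C)=C/CC[C@@H]1[C@@]2(C)CCC(=O)C(C)(C)[C@H]2CC[C@@]1(C)O)CC/C=C(\C)C(=O)OCc1cn(-c2ccccc2)nn1`) gives 95500 nM as the higher, and so weaker, of the two numbers. Within the data shown here, the only measured step, a 2.1-fold higher number from compound 1 to compound 2 (0.32 log units; beyond the scatter) on swapping ethynyl for 1-phenyl-1H-1,2,3-triazol-4-yl, was modest. Compound 3 (`C/C(=C\CC/C(C)=C/CC[C@@H]1[C@@]2(C)CCC(=O)C(C)(C)[C@H]2CC[C@@]1(C)O)CC/C=C(\C)C(=O)OCc1cn(-c2ccc(C)cc2)nn1`) differs from compound 2 by methyl in place of hydrogen on an aromatic carbon in a single small change: methyl in place of hydrogen on an aromatic carbon. The measured step shows nothing about a group added to that phenyl ring, so no shift beyond the scatter is expected in this assay here. The expected change is a 1.1-fold lower number from compound 2 to compound 3 (0.03 log units; within the scatter) in this estimate. The estimated value for compound 3 is 90000 nM with a range from 45000 nM to 180000 nM.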

Compound 3, half-maximal inhibitory concentration: > 150000 nM
Compound 3 gave a limit, no number; the forecaster's own chance of this, stated with the estimate: 20%; middle value at least 1.6-fold (0.22 log units) from the limit.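

The result for compound 3 in this assay is a limit of the assay, not a number: the limit of > 150000 nM in this assay, at which 1 of the 3 values shown sits. On these data alone, on the phenyl ring, methyl para to a large group gives an at least 1.5-fold higher number from compound 2 to compound 3 (0.19 log units; that floor lies within the scatter), so this change brought no stronger inhibition, though its true size stays unknown. Compared with the ethynyl group, the 1-(4-methylphenyl)-1H-1,2,3-triazol-4-yl group gives an at least 3.2-fold higher number from compound 1 to compound 3 (0.51 log units; beyond the scatter).

As far as these compounds go, the true value of compound 3 remains open. So does how a chlorine, a methoxy group or an amine at this same place on the ring would read.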